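Sulfonyl aryl exchanges within a shared core

The source may hold more compounds than are shown below. What is called first, only, known or untested is meant among the compounds shown, and "the series" means these compounds.

The three measured compounds share one core and differ only in the aryl group on the sulfonyl sulfur. Compound 1 `CC1CCN(c2c(S(=O)(=O)c3ccc(Cl)cc3)cnc3cc(Cl)ccc23)CC1` carries a 4-chlorophenyl there; in an assay on isolated protein for displacement of a labelled ligand from metabotropic glutamate receptor 5 (Homo sapiens), with a stated time of 60 min, tested at 1 uM (a lower number here means less inhibition, a higher number more inhibition at the concentration tested (going by the name of the read-out)), compound 1 gives 91%. Compound 2 `Cc1ccc(S(=O)(=O)c2cnc3cc(Cl)ccc3c2N2CCC(C)CC2)cc1C` carries a 3,4-dimethylphenyl, and in this assay compound 2 gives 86%. Compound 3 `CC1CCN(c2c(S(=O)(=O)c3cccc(C#N)c3)cnc3cc(Cl)ccc23)CC1` carries a 3-cyanophenyl, and in this assay compound 3 gives 94%. Compound 3 stands at the top of the three numbers, yet the steps are a number 3 percentage points higher from compound 1 to compound 3 (within the scatter) and a number 8 percentage points higher from compound 2 to compound 3 (within the scatter), both within the scatter, so no order among the three is claimed. The remaining step is likewise a number 5 percentage points lower from compound 1 to compound 2 (within the scatter), again within the scatter.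

Compound 4 `COc1ccc(S(=O)(=O)c2cnc3cc(Cl)ccc3c2N2CCC(C)CC2)cc1` has not been measured. It differs from compound 3 in one place: 4-methoxyphenyl in place of 3-cyanophenyl on a sulfonyl sulfur. Every measured step in the series is of this same kind, an exchange of the aryl on the sulfonyl sulfur, and none of them has moved the read-out beyond the scatter. The expectation for compound 4 in this assay is therefore no step beyond the scatter, a number 5 percentage points lower from compound 3 to compound 4 (within the scatter). Compound 4 is estimated at 89%, with a range from 78% to 97%.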

Compound 4, a percentage reported as inhibition, at one concentration (the size of the read-out at that concentration, not a potency): 79%
Beside the measured number, compound 4's estimate is 10 percentage points above it; the range from low to high includes it.
By their numbers in this assay, from the lowest: compounds 4, 2, 1 and 3 (each within the scatter of the next, the first and the last beyond it).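

Among the compounds shown here, compound 4 gives the first exchange on the sulfonyl sulfur to pass the scatter in this assay: 4-methoxyphenyl in place of 3-cyanophenyl is a number 15 percentage points lower from compound 3 to compound 4 (beyond the scatter), and methoxy in place of chloro on an aromatic carbon is a number 12 percentage points lower from compound 1 to compound 4 (beyond the scatter), so the aryl group at this position is not interchangeable in every case. The separation is only partial, since the step with 4-methoxyphenyl in place of 3,4-dimethylphenyl is a number 7 percentage points lower from compound 2 to compound 4 (within the scatter), leaving compound 4 unresolved from compound 2, which in turn is unresolved from compound 1 and compound 3. Nothing available bears on the reason for these steps.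

Going by these compounds, whether a cyclohexyl or a plain methyl on the sulfonyl sulfur, or a phenyl ring carrying a carboxylic acid or an amine, would hold the read-out near that of compound 3 remains open. With the read-out taken at a single concentration, the size of these steps also leaves open how far the compounds differ in potency.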